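Oxime Ether in Place of Pyrazine on the Shared Core

This account rests on a few compounds, and the source may have more. Where it says the series, first, only, none or still open, it means among the compounds named here.

Measured in a functional assay for activation of Alpha-1A adrenergic receptor (Homo sapiens), read by calcium flux; on this read-out lower numbers stand for an effect already at smaller amounts and higher numbers for an effect only at larger amounts of compound:
compound 1 `Cc1nc(-c2ccccc2NCC2=NCCN2)cs1`: 4.47 nM
compound 2 `Cc1ccsc1-c1ccccc1NCC1=NCCN1`: 0.851 nM
compound 3 `c1ccc(-c2cnccn2)c(NCC2=NCCN2)c1`: 4.57 nM

In this assay compound 3 and compound 1 cannot be told apart, a 1.0-fold higher number from compound 1 to compound 3 (0.01 log units; within the scatter), while compound 2 stands clearly apart from compound 3: a 5.4-fold higher number from compound 2 to compound 3 (0.73 log units; beyond the scatter). Compound 4 `CO/N=C/c1ccccc1NCC1=NCCN1` differs from compound 3 by a group of 4 heavy atoms (2 carbon, 1 nitrogen, 1 oxygen; no ring) in place of a group of 6 heavy atoms (4 carbon, 2 nitrogen; one six-membered aromatic ring with 2 hetero atoms), on an aromatic carbon. Among the measured compounds shown here, no measured step swaps a ring for a chain; all three exchange one aromatic ring for another, and the largest of them, a 5.3-fold lower number from compound 1 to compound 2 (0.72 log units; beyond the scatter), sets the scale of what such changes have done here. For the measured compounds named here, a step of at most modest size is therefore expected for compound 4, a 1.8-fold higher number from compound 3 to compound 4 (0.24 log units; within the scatter), with a wide range because the chain has no measured precedent. Compound 4 is estimated at 8 nM, between 2 nM and 40 nM.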

Compound 4, half-maximal effective concentration: 51.3 nM
For compound 4 the middle estimate is 6.4-fold (0.81 log units) below the measured one; measured number outside the range, above it.
By their numbers in this assay, from the lowest: compound 2; then compounds 1 and 3 (each within the scatter of the next); then compound 4.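

In this assay the oxime ether chain on this aromatic carbon produced larger steps than any exchange of one aromatic ring for another, with an 11-fold higher number from compound 3 to compound 4 (1.05 log units; beyond the scatter) and an 11-fold higher number from compound 1 to compound 4 (1.06 log units; beyond the scatter) and a 60-fold higher number from compound 2 to compound 4 (1.78 log units; beyond the scatter). All three ring compounds give lower numbers than compound 4, although pyrazin-2-yl and the entering chain have the same counts of hydrogen-bond donors and acceptors. Nothing measured here explains the loss.

The compounds shown leave open whether losing the ring or introducing the oxime ether drives these steps. A plain phenyl ring or an open chain ending in an amine on this carbon would help separate the two.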